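Hydroxyphenyl pyridines on DU-145 cells: positional notes

The source may report more compounds than this note shows. Statements on the series, on what has been measured and on what is new or still open speak of the compounds shown alone.

Working notes on a pair of hydroxyphenyl-bearing compounds examined in a functional assay on DU-145 cells (Homo sapiens) for cytotoxicity, read by CCK-8 assay; a lower number here means a stronger inhibitor, a higher number a weaker inhibitor. Compound 1 `Oc1cccc(-c2cc(-c3ccsc3)cc(-c3ccccc3O)n2)c1` is reported only as a limit in this assay, namely > 50000 nM. Compound 2 `Oc1ccccc1-c1cc(-c2cccnc2)cc(-c2ccccc2O)n1` likewise gives no number in this assay and stands at the limit > 50000 nM. Within the data shown here, both values shown thus rest on (the limit of > 50000 nM in this assay, at which 2 of the 2 values shown sit), so compound 2 stands exactly where every value so far stands, and no step between measured compounds exists to draw on. Compound 3 `Oc1cccc(-c2cc(-c3cccnc3)cc(-c3ccccc3O)n2)c1` is not yet measured; it differs from compound 2 by 3-hydroxyphenyl in place of 2-hydroxyphenyl on an aromatic carbon. With both measured values resting on the limit, nothing points to a change beyond scatter. The expected step from compound 2 to compound 3 in this assay is a step that the limit leaves unreadable from compound 2 to compound 3, most likely ending in another limit. Compound 3 is estimated at 60000 nM in this assay, with a range from 20000 nM to 200000 nM.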

Compound 3, half-maximal inhibitory concentration: 5580 nM
For compound 3 the middle estimate is 11-fold (1.03 log units) above the measured one, and the stated range ends above it.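

In this assay, among these compounds, 3-hydroxyphenyl in place of 2-hydroxyphenyl on the aromatic carbon next to the ring nitrogen gives an at least 8.9-fold lower number from compound 2 to compound 3 (0.95 log units; beyond the scatter), and compound 3 is the only compound here with a value that is not a limit. The other change, pyridin-3-yl in place of thiophen-3-yl, gives an at least 8.9-fold lower number from compound 1 to compound 3 (0.95 log units; beyond the scatter), so among these compounds a measurable value appears only where 3-hydroxyphenyl and pyridin-3-yl occur together. Both steps are minimum sizes, and their full size cannot be read, because each starts from a limit: the limit of > 50000 nM in this assay, at which 2 of the 3 values shown sit.

Whether the hydroxyl group itself matters at this position remains open, since the compounds shown offer no methoxy group or amine in its place. Also open, as far as these compounds go, is whether another group in place of pyridin-3-yl, such as a pyridine carrying a carboxylic acid, would keep the value of compound 3, 5580 nM.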